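Extending the Methyl on the Anilino Substituent

The source may report more compounds than this note shows. Statements on the series, on what has been measured and on what is new or still open speak of the compounds shown alone.

Compound 1 `Cc1ccc(NC2=CC(=O)c3nc4n(c3C2=O)[C@H]2OC[C@@H](O)[C@H]2OC4)cc1`: 3860 nM
Compound 2 `O=C1C(Nc2cccc(Cl)c2)=CC(=O)c2c1nc1n2[C@H]2OC[C@@H](O)[C@H]2OC1`: 7970 nM
Compound 3 `O=C1C(NC2CCCCC2)=CC(=O)c2c1nc1n2[C@H]2OC[C@@H](O)[C@H]2OC1`: > 16000 nM

Three compounds sharing one core were tested in a functional assay on HeLa cells (Homo sapiens) for inhibition, read by sulforhodamine B assay; a higher number here means a weaker inhibitor, a lower number a stronger inhibitor. The number for compound 3 is a limit of this assay, not a measured value. Of the two real numbers, compound 1 stands lowest, and the nearest, compound 2, lies beyond the usual scatter above it.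

Compound 4 `CCCc1ccc(NC2=CC(=O)c3nc4n(c3C2=O)[C@H]2OC[C@@H](O)[C@H]2OC4)cc1` is the next compound, differing from compound 1 by ethyl in place of hydrogen on a saturated chain carbon bound to an aromatic carbon. For the measured compounds named here, the only measured step, an at least 2.0-fold higher number from compound 2 to compound 3 (0.30 log units; that floor lies within the scatter), swaps an aromatic ring for a saturated one on the amine nitrogen and runs into (the limit of > 16000 nM in this assay, at which 1 of the 3 values shown sits). Going by the values given here, that step does not concern a change on a saturated chain carbon bound to an aromatic carbon, so no measured step bears on the move from compound 1 to compound 4. No shift beyond the scatter is expected. The expected step is a 1.2-fold lower number from compound 1 to compound 4 (0.08 log units; within the scatter). Compound 4 is estimated to give 3200 nM, with a range from 1200 nM to 8500 nM.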

Compound 4, half-maximal inhibitory concentration: 4990 nM
The estimate for compound 4 lay 1.6-fold (0.19 log units) below the measured number; the measured number falls inside the stated range.
By their numbers in this assay, from the lowest: compounds 1, 4 and 2 (each within the scatter of the next, the first and the last beyond it). At a limit, above all of these: compound 3.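

In this assay, ethyl in place of hydrogen on a saturated chain carbon bound to an aromatic carbon gives a 1.3-fold higher number from compound 1 to compound 4 (0.11 log units; within the scatter). For the compounds shown here, this is the first measured step at this place, and it shows that turning 4-methylphenyl into 4-propylphenyl on the amine nitrogen brings no shift beyond the usual scatter, so the longer chain is tolerated here in this assay. Nothing measured among these compounds accounts for this result.

On these data alone, whether a still longer chain, a branched group such as tert-butyl, or a chain ending in an amine or a carboxylic acid would give a similar number at this place remains open. Going by these compounds alone, this change also appears in only one pair, and whether it would read the same on the 3-chlorophenyl group of compound 2 is unknown.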